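The source may report more compounds than this note shows. Statements on the series, on what has been measured and on what is new or still open speak of the compounds shown alone.

Compound 1 `COc1cc(C(=O)c2ccc(-c3csc(N)n3)cc2-n2cncn2)cc(OC)c1OC` gives the lowest of the two numbers measured in a functional assay on HL-60 cells (Homo sapiens) for antiproliferative activity, read by MTT assay, with a stated time of 72 h (on this read-out higher numbers stand for weaker inhibition and lower numbers for stronger inhibition), at 4.8 nM. Its nearest neighbour is compound 2 `COc1cc(C(=O)c2ccc(-c3csc(NC(=O)[C@@H](N)C(C)C)n3)cc2-n2cncn2)cc(OC)c1OC`, which in this assay gives 110 nM; the step of a 23-fold higher number from compound 1 to compound 2 (1.36 log units; beyond the scatter) comes with (1-amino-2-methylpropyl)carbonyl in place of hydrogen on a nitrogen on an aromatic ring. Compound 3 `COc1cc(C(=O)c2ccc(-c3csc(NC(=O)[C@H](C)N)n3)cc2-n2cncn2)cc(OC)c1OC` has not yet been measured in this assay. It differs from compound 1 by (1-aminoethyl)carbonyl in place of hydrogen on a nitrogen on an aromatic ring, so the same kind of acylation of the amino group that separates compound 1 from compound 2, with (1-aminoethyl)carbonyl rather than (1-amino-2-methylpropyl)carbonyl. Among the compounds with values here, the only measured step that bears on this change is a 23-fold higher number from compound 1 to compound 2 (1.36 log units; beyond the scatter), which was large and beyond the scatter. Within the data shown here, because a 23-fold higher number from compound 1 to compound 2 (1.36 log units; beyond the scatter) is the single guide, the same direction is expected here, toward a higher number. Compound 3 is expected to move by about a 13-fold higher number from compound 1 to compound 3 (1.10 log units; beyond the scatter). Compound 3 is therefore estimated at 60 nM, within a range from 15 nM to 250 nM.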

Compound 3, half-maximal inhibitory concentration: 13 nM
Compound 3: the middle estimate sits 4.6-fold (0.66 log units) above what was measured, outside the stated range (below it).
By their numbers in this assay, from the lowest: compound 1; then compound 3; then compound 2.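

Within this assay, the price of acylating the amino group proves not to be fixed: (1-aminoethyl)carbonyl on this nitrogen costs only a 2.7-fold higher number from compound 1 to compound 3 (0.43 log units; beyond the scatter) and so takes up much less than the earlier step of a 23-fold higher number from compound 1 to compound 2 (1.36 log units; beyond the scatter) for the (1-amino-2-methylpropyl)carbonyl group. The acyl side chain itself therefore matters at this position, since methyl in place of isopropyl on the saturated chain carbon gives an 8.5-fold lower number from compound 2 to compound 3 (0.93 log units; beyond the scatter) even though the amide stays in place, while the free amino group of compound 1 still gives the lowest number of the three. Nothing shown here bears on what lies behind these differences.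

Two acyl groups cannot show whether the trend with the side chain continues to a bare aminoacetyl group, which has only hydrogen on that chain carbon, or reverses with a longer chain. As far as these compounds go, it also remains open whether the amine on the acyl group matters, as a plain acetyl group or a hydroxyl in place of that amine would test, and whether any acyl group can match compound 1.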